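A few compounds are considered here, and "the series" means these few. Any claim that something is new, unique, unknown or untested is made for them only; others in the source may bear on it.

Measured in a functional assay on MKN-45 cells (Homo sapiens) for antiproliferative activity (a lower number here means a stronger inhibitor, a higher number a weaker inhibitor), so far
- compound 1 `COc1ccc(S(=O)(=O)N2CCc3cccc(Nc4ccc(F)cc4)c32)cc1` gives 563 nM
- compound 2 `COc1ccc(S(=O)(=O)N2CCc3cccc(Nc4ccc([N+](=O)[O-])cc4)c32)cc1` gives 107 nM

Compound 2 holds the lower of the two numbers. Among the compounds with values here, the only measured step (a 5.3-fold lower number from compound 1 to compound 2 (0.72 log units; beyond the scatter)) is modest and beyond the scatter, and it replaces fluoro with nitro at the position changed next. Compound 3 `COC(=O)c1ccc(Nc2cccc3c2N(S(=O)(=O)c2ccc(OC)cc2)CC3)cc1` brings the change methoxycarbonyl in place of nitro on an aromatic carbon with methoxycarbonyl in place of nitro on an aromatic carbon, para to a large group. Within the data shown here, no measured compound carries methoxycarbonyl, so that single step is the only guide to size. Among the measured compounds shown here, a modest rise in this assay is expected, no larger than the step that produced compound 2 (a 5.3-fold lower number from compound 1 to compound 2 (0.72 log units; beyond the scatter)). The estimated change is a small one (a 1.9-fold higher number from compound 2 to compound 3 (0.27 log units; within the scatter)) and may not clear the scatter. Compound 3 is expected at 200 nM (estimated range 70 nM to 600 nM).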

Compound 3, half-maximal inhibitory concentration: 487 nM
Compound 3: middle estimate off by 2.4-fold (0.39 log units), on the low side, within the range that was stated.
By their numbers in this assay, from the lowest: compound 2; then compounds 3 and 1 (each within the scatter of the next).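

In this assay, the lower number seen with nitro does not carry over to methoxycarbonyl on the same aromatic carbon, para to a large group, with a 4.6-fold higher number from compound 2 to compound 3 (0.66 log units; beyond the scatter) beyond the scatter. Methoxycarbonyl and fluoro cannot be separated at this position, with a 1.2-fold lower number from compound 1 to compound 3 (0.06 log units; within the scatter) within the scatter, so among these three compounds only nitro stands apart, and the position responds to the identity of the group rather than to any replacement of fluoro. No measurement bears on the reason for the gap between nitro and methoxycarbonyl.

As far as these compounds go, it remains open whether nitrile, a carboxylic acid or an amine at this position would fall with compound 2 or with the other two compounds. From the compounds shown here alone, whether nitro keeps its advantage on other carbons of the same ring also remains open.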